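A few compounds are considered here, and "the series" means these few. Any claim that something is new, unique, unknown or untested is made for them only; others in the source may bear on it.

Of the compounds shown here, three have so far been measured in an assay on isolated protein for inhibition of RAC-alpha serine/threonine-protein kinase (Homo sapiens), read by mobility shift assay, tested at 30 uM; on this read-out lower numbers stand for less inhibition and higher numbers for more inhibition at the one concentration tested (going by the name of the read-out). Compound 1 `Cc1cc2c(c(NS(C)(=O)=O)nn2C)c(=O)[nH]1` gives 1% in this assay. Compound 2 `COCCNc1nc(C)cc2c1c(N)nn2C` gives 6%. Compound 3 `COCCNc1nc(-c2ccccc2)cc2c1c(N)nn2C` gives 8%, the highest of the three numbers, though its gaps to compound 2 and to compound 1 both lie within the scatter, so no order among the three can be drawn. For the measured compounds named here, the single step between measured compounds that differ in one place, a number 2 percentage points higher from compound 2 to compound 3 (within the scatter), is likewise within the scatter.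

Compound 4 `Cn1nc(N)c2cnc(-c3ccccc3)cc21` has not yet been measured. It differs from compound 3 in one place: hydrogen in place of (2-methoxyethyl)amino on an aromatic carbon. Going by the values given here, no measured pair removes this group, so no step bears directly on the change; the one step available, a number 2 percentage points higher from compound 2 to compound 3 (within the scatter), only shows how little the numbers have moved so far. On that basis no step beyond the scatter is expected, and the estimated change is a number 3 percentage points lower from compound 3 to compound 4 (within the scatter). Compound 4 is therefore expected to give about 5%, within a range from 0% to 15%.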

Compound 4, a percentage reported as inhibition, at one concentration (the size of the read-out at that concentration, not a potency): 4%
The estimate for compound 4 lay 1 percentage points above the measured number; the range from low to high includes it.
By their numbers in this assay, from the lowest: compounds 1, 4, 2 and 3 (each within the scatter of the next).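

Replacing the (2-methoxyethyl)amino group with hydrogen is the first change shown at this aromatic carbon, and in this assay it gives a number 4 percentage points lower from compound 3 to compound 4 (within the scatter). Compound 3 and compound 4 therefore cannot be told apart, so at this single concentration the result does not show that the (2-methoxyethyl)amino group contributes to inhibition of this kinase. No measurement is available that could account for this result.

On these data alone, it remains open whether any other group on this aromatic carbon, such as a carboxylic acid or a longer chain ending in a dimethylamino group, would shift the number beyond the scatter. As far as these compounds go, it also remains open whether replacing the phenyl group of compound 4 with another group, such as a pyridyl group, would do so.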